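Methyl for Methoxy on a Shared Nucleoside Core

The source may hold more compounds than are shown below. What is called first, only, known or untested is meant among the compounds shown, and "the series" means these compounds.

The measured compounds and their values in a functional assay on HL-60 cells (Homo sapiens) for antiproliferative activity, read by XTT assay, with a stated time of 72 h; a lower number here means a stronger inhibitor, a higher number a weaker inhibitor:
compound 1, `COc1ncnc2c1c(-c1ccsc1)cn2[C@@H]1O[C@H](CO)[C@@H](O)[C@H]1O`, 130 nM
compound 2, `COc1ncnc2c1c(-c1ccoc1)cn2[C@@H]1O[C@H](CO)[C@@H](O)[C@H]1O`, 150 nM
compound 3, `Cc1nc(N)c2c(-c3ccccc3)cn([C@@H]3O[C@H](CO)[C@@H](O)[C@H]3O)c2n1`, > 20000 nM

Compound 2 holds the highest of the two numbers given in this assay, with compound 1 nearest, and the two sit close together: a 1.2-fold higher number from compound 1 to compound 2 (0.06 log units; within the scatter). The value of compound 3 in this assay is a limit of the measurement rather than a number, and the limit of > 20000 nM in this assay, at which 1 of the 3 values shown sits, applies to it. Among the compounds with values here, compound 3 also differs from compound 2 in more than one place, so no single step connects them.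

Compound 4, `Cc1ncnc2c1c(-c1ccoc1)cn2[C@@H]1O[C@H](CO)[C@@H](O)[C@H]1O`, has not yet been measured. It differs from compound 2 by methyl in place of methoxy on an aromatic carbon. Within the data shown here, none of the measured steps touches this position: the only measured step, the exchange of a furan-3-yl for a thiophen-3-yl, stayed within the scatter, and compound 3 carries a methyl at a different position of the core together with other changes. The expectation for compound 4 therefore rests on the step at the five-membered ring alone, and the removal of the methoxy group is expected to weaken the compound modestly, as a 2.7-fold higher number from compound 2 to compound 4 (0.43 log units; beyond the scatter). Compound 4 is thus estimated at 400 nM in this assay, with a range from 100 nM to 2000 nM.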

Compound 4, half-maximal inhibitory concentration: > 15000 nM
Compound 4: no number, only a limit; the forecaster's own chance of this, stated with the estimate: 10%; at least 37-fold (1.57 log units) between middle value and limit.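

In this assay, within the data shown here, the group at this position of the shared core matters far more than the earlier compounds could show: methyl in place of methoxy gives an at least 100-fold higher number from compound 2 to compound 4 (2.00 log units; beyond the scatter). The exchange at the five-membered ring stayed small by comparison, with a 1.2-fold higher number from compound 1 to compound 2 (0.06 log units; within the scatter), so this aromatic carbon next to the ring nitrogen, and not the furan-3-yl or thiophen-3-yl group, is where the shown series loses its activity. As far as these compounds go, compound 4 has no number in this assay, only a limit, so the step gives a lower bound and its full size remains unknown: the limit of > 15000 nM in this assay, at which 1 of the 4 values shown sits.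

The compounds shown leave open whether the oxygen of the methoxy group is what counts, or whether an amine, a chlorine atom or a longer chain such as ethoxy at the same position would hold activity in the range of compound 2, which gives 150 nM. They also leave open whether the same exchange would cost as much with the thiophen-3-yl group of compound 1 in place of the furan-3-yl group.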